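The source may hold more compounds than are shown below. What is called first, only, known or untested is meant among the compounds shown, and "the series" means these compounds.

Working notes, series of tert-butyl ester oxindole derivatives. Compound 1 `CC(C)(C)OC(=O)/C=C1/C(=O)Nc2ccccc21` in a functional assay on OVCAR-3 cells (Homo sapiens) for inhibition, read by CCK-8 assay, with a stated time of 72 h, tested at 20 uM (a lower number here means less inhibition of growth, a higher number more inhibition of growth at the concentration tested), gives 59.6%. Going by the values given here, the only other measured member, compound 2 `CC(C)c1ccc2c(c1)/C(=C\C(=O)OC(C)(C)C)C(=O)N2`, gives 59.7% in this assay; on these two numbers compound 1 stands indistinguishable from compound 2, since the step of a number 0.1 percentage points higher from compound 1 to compound 2 (within the scatter) is a change in substitution on an aromatic carbon of the shared core that leaves the read-out essentially unchanged.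

The next member, compound 3 `CC(C)(C)OC(=O)/C=C1/C(=O)Nc2c(Cl)cccc21`, differs from compound 1 by chloro in place of hydrogen on an aromatic carbon. Among the compounds with values here, the one step that bears on it, a number 0.1 percentage points higher from compound 1 to compound 2 (within the scatter), also exchanges hydrogen on an aromatic carbon for a substituent and moves the read-out by nothing beyond the scatter. A step of similar size, in no clear direction, is therefore expected in this assay, namely a number 0.4 percentage points higher from compound 1 to compound 3 (within the scatter). Compound 3 is accordingly estimated at 60% in this assay, with a plausible range from 46% to 73%.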

Compound 3, percent growth inhibition at one concentration: 59.3%
Beside the measured number, compound 3's estimate is 0.7 percentage points above it; low and high end bracket the measured number.
By their numbers in this assay, from the lowest: compounds 3, 1 and 2 (each within the scatter of the next).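

In this assay, chloro in place of hydrogen on an aromatic carbon, ortho to a fused ring and meta to a fused ring, gives a step of a number 0.3 percentage points lower from compound 1 to compound 3 (within the scatter). Going by these compounds alone, the earlier compounds carried no substituent on this carbon, so this is the first reading for it: a single chlorine atom here leaves the growth inhibition read-out of the shared core essentially unchanged. Nothing available speaks to what lies behind this flat result.

From the compounds shown here alone, whether this carbon stays as undemanding with a larger or differently functional group, such as an amine, a carboxylic acid, a methoxy group or a longer chain, remains open. Also open, going by these compounds, is whether the tert-butyl ester or the amide hydrogen of the shared core matters more to this read-out than the substituents on the aromatic ring.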